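A few compounds are considered here, and "the series" means these few. Any claim that something is new, unique, unknown or untested is made for them only; others in the source may bear on it.

Measured compounds:
compound 1 `C=C(C)C(=O)Nc1cc2c(N3CCc4ccccc43)ncnc2cc1O[C@@H]1CCOC1` gives 16600 nM
compound 2 `CC/C=C/C(=O)Nc1cc2c(N3CCc4ccccc43)ncnc2cc1O[C@@H]1CCOC1` gives 10900 nM

Going by the values given here, in a functional assay on A549 cells (Homo sapiens) for antiproliferative activity, read by MTT assay, with a stated time of 72 h (a higher number here means a weaker inhibitor, a lower number a stronger inhibitor), compound 2 gives 10900 nM and stands level with compound 1, the only other compound measured. The move to compound 3 `CCC/C=C/C(=O)Nc1cc2c(N3CCc4ccccc43)ncnc2cc1O[C@@H]1CCOC1` is methyl in place of hydrogen on a saturated chain carbon, two bonds along the chain from a double-bonded chain carbon and turns but-1-en-1-yl into pent-1-en-1-yl. Methyl takes the place of hydrogen on a saturated chain carbon, two bonds along the chain from a double-bonded chain carbon. Among the compounds with values here, one measured step bears on this, a 1.5-fold lower number from compound 1 to compound 2 (0.18 log units; within the scatter) and it also changed the group on the carbonyl carbon. That step gives no direction to follow, and nothing measured yet covers a longer chain. No change beyond the scatter is therefore expected. The expected step is a 1.1-fold lower number from compound 2 to compound 3 (0.04 log units; within the scatter) and it stays small. The estimate for compound 3 is 10000 nM with 4500 nM to 22000 nM as the expected range.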

Compound 3, half-maximal inhibitory concentration: 9110 nM
Compound 3: middle estimate off by 1.1-fold (0.04 log units), on the high side, within the range that was stated.
By their numbers in this assay, from the lowest: compounds 3, 2 and 1 (each within the scatter of the next).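

In this assay the added methyl, on a saturated chain carbon, two bonds along the chain from a double-bonded chain carbon, gives a 1.2-fold lower number from compound 2 to compound 3 (0.08 log units; within the scatter) and so adds to the picture: this position accepts pent-1-en-1-yl in place of but-1-en-1-yl with no step beyond the scatter. Changing the group on the carbonyl carbon gives a 1.8-fold lower number from compound 1 to compound 3 (0.26 log units; within the scatter) and so leaves all three groups on that carbon within the scatter of one another. No measurement in hand offers an explanation for these numbers.

The compounds shown leave open whether a longer chain than pent-1-en-1-yl would give a step beyond the scatter. They also leave open what an amine or a carboxylic acid at the end of the chain would do.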